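Ester double-bond geometry, compound 1 to compound 3

This account rests on a few compounds, and the source may have more. Where it says the series, first, only, none or still open, it means among the compounds named here.

Measured so far:
- compound 1 `C=CC(=C)CC[C@@H]1[C@@]2(C)CCC[C@](C)(COC(=O)/C=C/c3ccc(O)cc3)[C@@H]2CC[C@@]1(C)O` gives 20400 nM
- compound 2 `C=C1CC[C@@H]2[C@](C)(CCC[C@@]2(C)C(=O)O)[C@H]1CC/C(C)=C/COC(C)=O` gives > 40000 nM

Of the compounds shown here, two have been measured in a functional assay on A549 cells (Homo sapiens) for cytotoxicity, read by MTT assay, with a stated time of 48 h; a lower number here means a stronger inhibitor, a higher number a weaker inhibitor. Among the measured compounds shown here, compound 1 gives 20400 nM, and this is the only numerical value in the set. For compound 2 the assay reports only a limit, > 40000 nM. For the measured compounds named here, the only other entry therefore sits at the limit of > 40000 nM in this assay, at which 1 of the 2 values shown sits, so compound 1 stands as the sole fixed point; compound 2 does not give a second number against which a step could be measured, and no step between measured compounds is available.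

Compound 3 `C=CC(=C)CC[C@@H]1[C@@]2(C)CCC[C@](C)(COC(=O)/C=C\c3ccc(O)cc3)[C@@H]2CC[C@@]1(C)O` has not yet been tested. the two compounds have the same atoms and bonds and differ only in configuration as drawn: 1 of 6 stereo elements differ; a double bond is drawn E in compound 1 and Z in compound 3 The double bond of the ester side chain is drawn E in compound 1 and Z in compound 3; nothing enters and nothing leaves.

Going by the values given here, with no measured step to build on, no change beyond the usual scatter of this assay is expected in either direction. Compound 3 is expected to give about 20000 nM, in the range 8000 nM to 50000 nM. The step of a 1.0-fold lower number from compound 1 to compound 3 (0.01 log units; within the scatter) is expected to stay within the scatter of repeated measurements.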

Compound 3, half-maximal inhibitory concentration: 17100 nM
Estimate against measurement, compound 3: 1.2-fold (0.07 log units) above, within the range that was stated.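

In this assay, the ester side chain of compound 1 now has its first readable step, a change of the double bond from E to Z alone: a 1.2-fold lower number from compound 1 to compound 3 (0.08 log units; within the scatter). At this position, E and Z cannot be told apart by this read-out, a finding that the earlier single number and limit could not supply, and the comparison is a clean one: the fact that compounds 1 and 3 differ only in the configuration as drawn. Compound 2 remains a limit of the assay rather than a number, so it adds no second step to this reading: the limit of > 40000 nM in this assay, at which 1 of the 3 values shown sits.

Going by these compounds, whether any change to the ester side chain can move the value beyond the scatter remains open, for example an amide in place of the ester, or a methoxy group or an amine in place of the hydroxyl on the aromatic ring. Also open, on these data alone, is whether the result for the double bond geometry holds in a series with a different ester side chain, as the present reading rests on a single pair of compounds in one cell line.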